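The source may hold more compounds than are shown below. What is called first, only, known or untested is meant among the compounds shown, and "the series" means these compounds.

In an ADME assay on Huh-7 cells (Homo sapiens) for cytotoxicity, read by MTT assay (a lower number here means that less compound is tolerated, a higher number that more compound is tolerated), compound 1 (`CC(C)(C)C(=O)N(CCCCCCN1C[C@H](O)[C@@H](O)[C@H](O)[C@H]1CO)C1CCCCC1`) gives 500000 nM. Compound 2 (`NC(=O)N(CCCCCCN1C[C@H](O)[C@@H](O)[C@H](O)[C@H]1CO)C1CCCCC1`) gives > 500000 nM, which is a limit of the assay and not a number. Compound 2 therefore has no exact place on the scale, and the readings so far end at the limit of > 500000 nM in this assay, at which 1 of the 2 values shown sits.

Compound 3 (`CC(C)(C)NC(=O)N(CCCCCCN1C[C@H](O)[C@@H](O)[C@H](O)[C@H]1CO)C1CCCCC1`) differs from compound 2 by tert-butyl in place of hydrogen on an amide-type nitrogen. Within the data shown here, only one measured step bears on this change: a number no lower from compound 1 to compound 2 (the limit leaves the size open), with amino in place of tert-butyl on a carbonyl carbon. Its size cannot be read, and it concerns a different place, so it offers only weak guidance. Compound 1 carries a tert-butyl and still gives 500000 nM, so the tert-butyl in compound 3 is not expected to lower the value much. No step beyond the scatter is expected in this assay, in either direction. The expected change is a number no higher from compound 2 to compound 3 (the limit leaves the size open). A result reported only as a limit is also quite likely. For compound 3 the estimate is 500000 nM, with an expected range of 200000 nM to 800000 nM.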

Compound 3, half-maximal cytotoxic concentration: > 500000 nM
Compound 3: no number, only a limit; the forecaster's own chance of this, stated with the estimate: 60%; the middle value lies on the limit itself.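

In this assay, tert-butyl on the amide-type nitrogen leaves compound 3 with a limit of the assay and not a number, so the larger group does not bring this position into the readable range. Steps between two limits cannot be read, so neither the size nor the direction of the change from hydrogen to tert-butyl can be stated. Against the only exact reading in the series the comparison gives a direction and no size, a number no lower from compound 1 to compound 3 (the limit leaves the size open), with (tert-butyl)amino in place of tert-butyl on a carbonyl carbon, and this position cannot be ranked further because the readings now gather at the top of the scale: the limit of > 500000 nM in this assay, at which 2 of the 3 values shown sit.

Going by these compounds, whether a phenyl ring or a longer chain on the amide-type nitrogen, or a basic amine on the same carbonyl carbon, would give an exact number in this assay stays open. Also open, on these data alone, is how far compound 2 and compound 3 lie past their limits, and so whether the two differ at all.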